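The compounds below may be only part of what the source reports. "The series", "measured", "known", "first", "only" and "open" are said of these compounds alone.

Measured compounds: compound 1 `CCOC(=O)C1=C(Nc2ccccc2)S/C(=C\c2ccc(O)c(O)c2)C1=O` gave 6100 nM in a functional assay on JAR cells (Homo sapiens) for inhibition, read by MTT assay, with a stated time of 72 h; a higher number here means a weaker inhibitor, a lower number a stronger inhibitor; compound 2 `CCOC(=O)C1=C(Nc2ccccc2)S/C(=C\c2ccc([N+](=O)[O-])c(O)c2)C1=O` gave 12700 nM; compound 3 `CCOC(=O)C1=C(Nc2ccccc2)S/C(=C\c2ccc[nH]2)C1=O` gave 9500 nM.

Compound 3 sits close to both of the others: the step of a 1.6-fold higher number from compound 1 to compound 3 (0.19 log units; within the scatter) lies within the scatter, and the values of compound 3 and compound 2 also lie within the scatter of each other, so none of the three can be separated with confidence on these numbers.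

Compound 4 `CCOC(=O)C1=C(Nc2cccc([N+](=O)[O-])c2)S/C(=C\c2ccc[nH]2)C1=O` differs from compound 3 by nitro in place of hydrogen on an aromatic carbon. Within the data shown here, the only measured step that involves a nitro group is a 2.1-fold higher number from compound 1 to compound 2 (0.32 log units; beyond the scatter), where the nitro replaced a hydroxy group on the other aromatic ring of the core, not on the phenyl bound to the nitrogen. That step was modest and only just beyond the scatter, and it concerns a different ring and a different leaving group, so it bears on the present change only loosely. Nothing measured here reports a substituent on the anilino phenyl at all.

The author therefore expects no step beyond the scatter, with a slight lean toward a higher number: a 1.3-fold higher number from compound 3 to compound 4 (0.10 log units; within the scatter). For compound 4 the estimate in this assay is 12000 nM, with a range from 5000 nM to 30000 nM.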

Compound 4, half-maximal inhibitory concentration: 10100 nM
Beside the measured number, compound 4's estimate is 1.2-fold (0.07 log units) above it; measured number inside the range.
By their numbers in this assay, from the lowest: compounds 1, 3, 4 and 2 (each within the scatter of the next, the first and the last beyond it).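

The change from phenyl to 3-nitrophenyl, on an aromatic carbon meta to a large group, gives a 1.1-fold higher number from compound 3 to compound 4 (0.03 log units; within the scatter) in this assay, so the two compounds cannot be separated on these numbers. Among these compounds, compounds 1, 2 and 3 all keep an unsubstituted phenyl on the nitrogen and differ only in the group on the double-bonded chain carbon, so this is the first reading of a change on that ring, and at this position in this assay the nitro group leaves no measurable mark on the pyrrole compound. No measurement available here offers an explanation for this result.

As far as these compounds go, it remains open whether the same result would hold with a different group in this place, such as an amine, a carboxylic acid or a methoxy group, since a single nitro group cannot stand for substituents in general. From the compounds shown here alone, it is equally open whether 3-nitrophenyl would behave the same way on the nitrogen of compound 1, which carries 3,4-dihydroxyphenyl in place of the pyrrole.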